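From Propylsulfanyl to Butylamino on the Shared Core

The source may hold more compounds than are shown below. What is called first, only, known or untested is meant among the compounds shown, and "the series" means these compounds.

Compound 1 `CCCSc1nc(N)c2nc(O)n(Cc3ccccc3)c2n1` holds the lowest of the two values recorded here in a functional assay on the whole organism for activation, with Mus musculus as the target (a higher number here means that more compound is needed for the effect, a lower number that less compound is needed), where compound 1 gives 0.1 mg/kg. Its nearest neighbour, compound 2 `Nc1ncnc2c1nc(O)n2Cc1ccc(Cl)cc1`, gives 30 mg/kg in this assay, a gap beyond the scatter; the two structures differ in more than one place, so the numbers alone are what they show. Compound 3 `CCCCNc1nc(N)c2nc(O)n(Cc3ccccc3)c2n1` has not yet been measured. It differs from compound 1 as follows: butylamino in place of propylsulfanyl on an aromatic carbon. Going by the values given here, no measured pair in this set isolates that exchange, so there is no directly comparable step to lean on. Because compound 1 sits at 0.1 mg/kg, the account expects compound 3 to remain in the same region, with the step of a 2.0-fold higher number from compound 1 to compound 3 (0.30 log units; within the scatter) expected to be small, leaning if anything toward a somewhat higher dose, but not clearly beyond the scatter. For compound 3 the estimated minimum effective dose is 0.2 mg/kg, with a range from 0.03 mg/kg to 1.5 mg/kg.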

Compound 3, minimum effective dose: 0.1 mg/kg
For compound 3 the middle estimate is 2.0-fold (0.30 log units) above the measured one; the range from low to high includes it.
By their numbers in this assay, from the lowest: compounds 1 and 3 (each within the scatter of the next); then compound 2.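

In this assay, going by these compounds alone, the exchange of propylsulfanyl for butylamino on the aromatic carbon between two ring nitrogen atoms gives no change at the digits printed from compound 1 to compound 3 (within the scatter), the first step in this set to isolate a single change at this position. It shows that, on the shared core, a chain joined through sulfur and a longer chain joined through nitrogen give readings within the scatter of each other, even though butylamino brings a hydrogen-bond donor that propylsulfanyl lacks. Nothing available here bears on why the two groups read alike.

The compounds shown leave open how far this tolerance extends: whether a shorter propylamino chain, a longer hexylamino chain, a butoxy group joined through oxygen, a benzylamino group or a carboxylic acid at the same carbon would also stay in this region remains unknown. Within the data shown here, they also leave open whether the exchange of propylsulfanyl for butylamino would read the same way on a core that differs elsewhere, since only this one pair isolates it.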